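Swapping a diol chain for an acetamide

This account rests on a few compounds, and the source may have more. Where it says the series, first, only, none or still open, it means among the compounds named here.

Compound 1 `Cn1ncc(Cl)c1-c1cc(C(=O)N[C@@H]2CN[C@H](CC(O)CO)C[C@H]2c2ccc(F)c(F)c2)oc1Cl`: 690 nM
Compound 2 `Cn1ncc(Cl)c1-c1cc(C(=O)N[C@@H]2CN[C@H](CC(O)CO)C[C@H]2c2ccc(Cl)c(Cl)c2)oc1Cl`: 1610 nM

These two numbers come from a functional assay on OVCAR-8 cells (Homo sapiens) for antiproliferative activity; a lower number here means a stronger inhibitor, a higher number a weaker inhibitor. Compound 1, at 690 nM, has the lower number of the pair, which makes it the stronger inhibitor so far.

Compound 3 `CC(=O)NCC[C@@H]1C[C@@H](c2ccc(F)c(F)c2)[C@H](NC(=O)c2cc(-c3c(Cl)cnn3C)c(Cl)o2)CN1` keeps the core of compound 1 and its 3,4-difluorophenyl group, but alters the side chain: acetamidomethyl in place of 1,2-dihydroxyethyl on a saturated chain carbon bound to a saturated ring carbon. Cut one bond further out, the same change reads 2,3-dihydroxypropyl to 2-acetamidoethyl.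

Within the data shown here, no measured pair tests this change directly. Among the measured compounds shown here, the only guide is a 2.3-fold higher number from compound 1 to compound 2 (0.37 log units; beyond the scatter), a modest step made at the 3,4-difluorophenyl group rather than on this chain. It gives a rough idea of size but no direction for the new change, so a shift in either direction remains possible in this assay. The expected step is a 1.0-fold higher number from compound 1 to compound 3 (0.01 log units; within the scatter), with no clear move beyond the scatter as the central expectation. Compound 3 is therefore estimated at 700 nM, with an expected range of 250 nM to 2000 nM.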

Compound 3, half-maximal inhibitory concentration: 880 nM
Compound 3: middle estimate off by 1.3-fold (0.10 log units), on the low side; the range from low to high includes it.
By their numbers in this assay, from the lowest: compounds 1, 3 and 2 (each within the scatter of the next, the first and the last beyond it).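

Among these compounds, this is the first direct reading at the chain itself, since the earlier pair changed only the 3,4-difluorophenyl group. In this assay, replacing 1,2-dihydroxyethyl with acetamidomethyl gives a 1.3-fold higher number from compound 1 to compound 3 (0.11 log units; within the scatter), so compound 1 and compound 3 cannot be told apart at this place on a saturated chain carbon bound to a saturated ring carbon. The swap is not a small edit on paper, taking a group with 2 hydrogen-bond donors and 2 hydrogen-bond acceptors to one with 1 of each, and adding a nitrogen and a double bond outside aromatic rings, yet the antiproliferative reading stays within the scatter, and nothing measured here accounts for that.

From the compounds shown here alone, one pair cannot show how much this chain can vary, so it remains open whether a chain ending in a free amine or a carboxylic acid, or a longer acetamide chain, would also stay this close to compound 1. Going by these compounds, it is also open whether the acetamidomethyl group would behave the same way alongside the 3,4-dichlorophenyl group of compound 2.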